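The compounds below may be only part of what the source reports. "The series", "measured", "known", "first", "only" and "open" are said of these compounds alone.

Measured in an ADME assay on Huh7.5.1 cells (Homo sapiens) for cytotoxicity, read by WST assay, with a stated time of 48 h; on this read-out higher numbers stand for lower toxicity in this test and lower numbers for higher toxicity in this test:

- Compound 1 `Cc1c(-c2ccc(Oc3ccc(N4CCCCC4)cc3)c(F)c2)[nH]c2cccc(F)c2c1=O`: > 10000 nM
- Compound 2 `CCCN(CC)c1ccc(Oc2ccc(-c3[nH]c4cccc(F)c4c(=O)c3C)cc2F)cc1`: > 10000 nM

Both results are limits, not numbers. Compound 2 stands at the limit of > 10000 nM, and so far nothing lies elsewhere: the limit of > 10000 nM in this assay, at which 2 of the 2 values shown sit.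

Compound 3 `CCN(C)c1ccc(Oc2ccc(-c3[nH]c4cccc(F)c4c(=O)c3C)cc2F)cc1` differs from compound 2 by hydrogen in place of ethyl on a saturated chain carbon bound to a nitrogen on an aromatic ring, which turns propyl to methyl and ethyl(propyl)amino to ethyl(methyl)amino. Among the compounds with values here, the one measured step at this amino group is a step that the two limits leave unreadable from compound 1 to compound 2. It gives no size to carry over, so no change beyond the scatter is expected in this assay, and the assay will probably report a limit again. The expected step is a number no higher from compound 2 to compound 3 (the limit leaves the size open). For compound 3 the estimated value is 10000 nM, with an expected range of 5000 nM to 20000 nM.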

Compound 3, half-maximal cytotoxic concentration: > 10000 nM
Compound 3 gave a limit, no number; the forecaster's own chance of this, stated with the estimate: 85%; the middle value sits exactly at the limit.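

No step can be read among compound 1, compound 2 and compound 3 in this assay, since all three results are limits, not numbers: the limit of > 10000 nM in this assay, at which 3 of the 3 values shown sit.

The compounds shown leave open whether changing the amino group shifts the cytotoxic concentration at all.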